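The source may report more compounds than this note shows. Statements on the series, on what has been measured and on what is new or still open speak of the compounds shown alone.

Measured so far:
compound 1 `Cc1ccc(C2CCN(CC(=O)Nc3cccc(C)c3)CC2)nc1`: "not active" (no number reported)
compound 2 `Cc1cccc(NC(=O)CN2CCC(c3ccccc3)CC2)c1`: 15.4 nM

In a functional assay on cells for agonist activity at D(4) dopamine receptor (Homo sapiens), read by TR-FRET and cAMP accumulation, with a stated time of 30 min (on this read-out higher numbers stand for an effect only at larger amounts of compound and lower numbers for an effect already at smaller amounts), compound 2 gives 15.4 nM, the only numerical result in the set. In this assay, among the measured compounds shown here, compound 1 is recorded as "not active" (no number reported), with no number behind it, so no step between compound 1 and compound 2 can be sized. For the measured compounds named here, no pair of measured compounds differing in a single place is available.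

Compound 3 `Cc1cccc(NC(=O)CN2CCC(c3ccc(Cl)cc3)CC2)c1` differs from compound 2 by chloro in place of hydrogen on an aromatic carbon. Going by the values given here, with no comparable measured step to lean on, the expectation is a modest gain at most, or none beyond the scatter, since compound 2 already gives 15.4 nM. The expected step is a 1.5-fold lower number from compound 2 to compound 3 (0.19 log units; within the scatter). Compound 3 is estimated at 10 nM, with a range from 3 nM to 40 nM.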

Compound 3, half-maximal effective concentration: "not active" (no number reported)
The entry for compound 3 holds no number; there is nothing to compare the estimate with.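

In this assay, among the compounds shown here, compound 3 gives "not active" (no number reported) and so, like compound 1, offers no number, leaving no step from compound 2 readable. Nothing shown bears on this result. The compounds shown leave open whether any other replacement on the phenyl of compound 2 keeps a numerical result.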